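Nitro for Chloro on the Pendant Phenyl Ring

The compounds below may be only part of what the source reports. "The series", "measured", "known", "first", "only" and "open" are said of these compounds alone.

Compound 1 `Nc1scc(-c2ccccc2F)c1C(=O)c1ccccc1`: 68%
Compound 2 `Nc1scc(-c2cccc(Cl)c2)c1C(=O)c1ccccc1`: 52%
Compound 3 `Nc1scc(-c2ccc(Cl)cc2)c1C(=O)c1ccccc1`: 51%

Among these three, compound 3 holds the lowest number in a functional assay on CHO cells for agonist activity at adenosine receptor A1 (Homo sapiens), read by fluorescence and ERK phosphorylation, with stated times of 30 min and 1.5 h, tested at 10 uM (on this read-out higher numbers stand for a stronger effect at the one concentration tested and lower numbers for a weaker effect), though its gap to compound 2 is within the scatter; only compound 1 is clearly higher, by a number 17 percentage points lower from compound 1 to compound 3 (beyond the scatter). Compound 4 `Nc1scc(-c2ccc([N+](=O)[O-])cc2)c1C(=O)c1ccccc1` differs from compound 3 by nitro in place of chloro on an aromatic carbon. Going by the values given here, no measured step exchanges one kind of group for another; the one step on the same ring, a number 1 percentage points lower from compound 2 to compound 3 (within the scatter), only moved the chloro and changed little, and a number 16 percentage points lower from compound 1 to compound 2 (beyond the scatter) was modest. The step to compound 4 is therefore expected to stay within the scatter, a number 1 percentage points lower from compound 3 to compound 4 (within the scatter). Compound 4 is estimated at 50%, with a range from 30% to 70%.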

Compound 4, a percentage reported as activity, at one concentration (the size of the read-out at that concentration, not a potency): 47%
The estimate for compound 4 lay 3 percentage points above the measured number; the measured number falls inside the stated range.
By their numbers in this assay, from the lowest: compounds 4, 3 and 2 (each within the scatter of the next); then compound 1.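

Here one kind of group replaces another at this position, rather than the same chloro being moved, and this assay gives a number 4 percentage points lower from compound 3 to compound 4 (within the scatter) for that exchange. At this place, para to a large group, the read-out therefore does not separate a chloro of one heavy atom from a nitro of three heavy atoms with two hydrogen-bond acceptors. Nothing available explains why these two groups read alike. From the compounds shown here alone, whether an amine or a carboxylic acid at this place would read the same stays open. So does whether a nitro elsewhere on this ring would match the chloro there.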